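Swapping a 4-Chlorobenzyl for an Allyl Chain

The source may report more compounds than this note shows. Statements on the series, on what has been measured and on what is new or still open speak of the compounds shown alone.

Compound 1 `COc1ccc([C@@H]2CC(=O)c3c(O)cc(OCc4cn(Cc5ccccc5Cl)nn4)cc3O2)cc1O`: 6140 nM
Compound 2 `COc1ccc([C@@H]2CC(=O)c3c(O)cc(OCc4cn(Cc5ccc(Cl)cc5)nn4)cc3O2)cc1O`: 17800 nM
Compound 3 `COc1ccc([C@@H]2C/C(=N\O)c3c(O)cc(OCc4cn(-c5ccccc5)nn4)cc3O2)cc1O`: 6130 nM

In a functional assay on RAW264.7 cells (Mus musculus) for inhibition, read by Griess assay, with stated times of 2 h and 24 h (on this read-out higher numbers stand for weaker inhibition and lower numbers for stronger inhibition), compound 2 gives 17800 nM, the highest of the three numbers; compound 1 and compound 3 both sit lower, each beyond the scatter. Compound 4 `C=CCn1cc(COc2cc(O)c3c(c2)O[C@H](c2ccc(OC)c(O)c2)CC3=O)nn1` is the next step: vinyl in place of 4-chlorophenyl on a saturated chain carbon bound to an aromatic nitrogen. Among the measured compounds shown here, the only measured step at this position, a 2.9-fold higher number from compound 1 to compound 2 (0.46 log units; beyond the scatter), exchanged one chlorophenyl for another rather than removing the ring, so it bears only loosely on this change. For the measured compounds named here, compound 3 differs from compound 2 in more than one place, and its value shows only that a lower number is reachable. Going by the values given here, with no step that removes the ring, compound 4 is expected to stay close to compound 2, and the step of a 1.1-fold higher number from compound 2 to compound 4 (0.05 log units; within the scatter) is expected to be small. Compound 4 is estimated at 20000 nM, within 6000 nM to 60000 nM.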

Compound 4, half-maximal inhibitory concentration: 13800 nM
Estimate against measurement, compound 4: 1.4-fold (0.16 log units) above; the range from low to high includes it.
By their numbers in this assay, from the lowest: compounds 3 and 1 (each within the scatter of the next); then compounds 4 and 2 (each within the scatter of the next).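

In this assay, trading the 4-chlorobenzyl group for allyl removes the whole aromatic ring, yet the result is only a 1.3-fold lower number from compound 2 to compound 4 (0.11 log units; within the scatter), so this ring is not needed to hold the level seen for compound 2. The 2-chlorobenzyl group is a different case: a 2.2-fold higher number from compound 1 to compound 4 (0.35 log units; beyond the scatter) shows that allyl does not match compound 1. No measurement here explains either step. From the compounds shown here alone, whether an amine, a carboxylic acid or a longer chain at this place would give a lower number stays open.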